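The source may hold more compounds than are shown below. What is called first, only, known or untested is meant among the compounds shown, and "the series" means these compounds.

Compound 1 `CC(=O)c1sc(NC(C)C)c(C#N)c1N` reaches only the limit of an assay for inhibition of Maternal embryonic leucine zipper kinase (Homo sapiens), read by ADP-Glo, with a stated time of 0.5 h (on this read-out higher numbers stand for weaker inhibition and lower numbers for stronger inhibition), giving > 5000 nM, which is a limit rather than a number. Among the compounds with values here, compound 2 `CC(C)Nc1sc(C(=O)c2ccco2)c(N)c1C#N` gives 1350 nM in this assay, the only actual number among the values so far. Within the data shown here, the step of an at least 3.7-fold lower number from compound 1 to compound 2 (0.56 log units; beyond the scatter) is the one measured change at the carbonyl carbon. Compound 3 `CC(C)Nc1sc(C(=O)c2ccc(I)s2)c(N)c1C#N` differs from compound 2 by 5-iodothiophen-2-yl in place of furan-2-yl on a carbonyl carbon, an exchange of one five-membered aromatic ring for another at that same place. With one bearing step, a small shift toward a lower number, near the scatter, is expected. Compound 3 is estimated at 800 nM, between 250 nM and 2500 nM, a step of a 1.7-fold lower number from compound 2 to compound 3 (0.23 log units; within the scatter).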

Compound 3, half-maximal inhibitory concentration: 112 nM
For compound 3 the middle estimate is 7.1-fold (0.85 log units) above the measured one, and the stated range ends above it.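

The choice of ring on the carbonyl carbon counts, not merely the presence of a ring there: in this assay, exchanging one five-membered aromatic ring for another gives a 12-fold lower number from compound 2 to compound 3 (1.08 log units; beyond the scatter). Measured against the methyl group, the total change is an at least 44-fold lower number from compound 1 to compound 3 (1.64 log units; beyond the scatter). Compound 1 stands at a limit, so this total is only a minimum: the limit of > 5000 nM in this assay, at which 1 of the 3 values shown sits.

The exchange brings in sulfur and iodine together, so the compounds shown cannot say which of the two carries the gain. A plain thiophen-2-yl, without iodine, would separate them.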